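Methoxy on a Fused Core: Expected Solubility of Compound 4

The source may hold more compounds than are shown below. What is called first, only, known or untested is meant among the compounds shown, and "the series" means these compounds.

Three sulfonamides have been measured in a physicochemical assay for solubility, read by chemiluminescence, measured as kinetic solubility; a lower number here means a less soluble compound, a higher number a more soluble compound. Compound 1, `Cn1ncc2c(NS(=O)(=O)c3cccc(Cl)c3Cl)cccc21`, gives 170000 nM. Compound 2, `COc1nn(C)c2cccc(NS(=O)(=O)c3cccc(Cl)c3Cl)c12`, gives 80000 nM. Compound 3, `Cn1ncc2c(NS(=O)(=O)c3cccc(Cl)c3Cl)ncnc21`, gives 476000 nM, the highest of the three; its nearest neighbour is compound 1 and its most distant is compound 2, both of which are beyond the scatter. Compound 4, `COc1nn(C)c2ncnc(NS(=O)(=O)c3cccc(Cl)c3Cl)c12`, has not yet been measured in this assay.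

Compound 1 and compound 2 differ in one place: methoxy in place of hydrogen on an aromatic carbon. That change produced a 2.1-fold lower number from compound 1 to compound 2 (0.33 log units; beyond the scatter).

Compound 3 and compound 4 differ by the same change: methoxy in place of hydrogen on an aromatic carbon. The place is described in the same words for both pairs, so the two changes are of the same kind, made on two different cores. The difference between the core of compound 1 and the core of compound 3 is not broken down here; what can be said is that compound 3 gives 476000 nM while compound 1 gives 170000 nM.

The expectation for compound 4 rests on a single precedent, the step from compound 1 to compound 2. Because that step was a 2.1-fold lower number from compound 1 to compound 2 (0.33 log units; beyond the scatter), a step of similar size is expected from compound 3 to compound 4, namely a 2.1-fold lower number from compound 3 to compound 4 (0.32 log units; beyond the scatter). Within the data shown here, with only one earlier example, the range is kept wide. Compound 4 is therefore estimated at 230000 nM in this assay, with a plausible span from 100000 nM to 450000 nM.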

Compound 4, solubility: >= 581000 nM
Compound 4: only a limit was reported; the forecaster's own chance of this, stated with the estimate: 5%; at least 2.5-fold (0.40 log units) between middle value and limit.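

On the core of compound 1, methoxy in place of hydrogen on an aromatic carbon gave a 2.1-fold lower number from compound 1 to compound 2 (0.33 log units; beyond the scatter), whereas the same change on the core of compound 3 gave an at least 1.2-fold higher number from compound 3 to compound 4 (0.08 log units; that floor lies within the scatter). This shows that the lower number seen on the first core did not carry over to the second, so in these two pairs the result of the change depended on the core that received it, and one pair was not a reliable guide to the other. In this assay compound 4 gives >= 581000 nM, which is a limit and not a number, so this result does not show how large the step from compound 3 really is, nor whether the two compounds stand clearly apart, and it gives no reason why the two cores responded differently: the limit of >= 581000 nM in this assay, at which 1 of the 4 values shown sits.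

The compounds shown cover only hydrogen and methoxy at this place on two cores, so it remains open whether the two cores would also part ways with an ethoxy group, an amine or a carboxylic acid there. As far as these compounds go, with just two pairs, it also remains open how the change would behave on a third core, or whether either result is typical of this series.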